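Swapping the Fused Core Beside the Piperidine Sulfonamide

The compounds below may be only part of what the source reports. "The series", "measured", "known", "first", "only" and "open" are said of these compounds alone.

Compound 1 `O=C(NCc1ccc(S(=O)(=O)c2ccccc2)cc1)c1cc2ncccc2s1` gives > 10000 nM in a functional assay on A2780 cells (Homo sapiens) for inhibition, read by sulforhodamine B assay, with a stated time of 72 h (a higher number here means a weaker inhibitor, a lower number a stronger inhibitor), which is the limit of > 10000 nM in this assay, at which 1 of the 3 values shown sits, rather than a number. Compound 3 `O=C(NCc1ccc(S(=O)(=O)c2ccc(F)c(F)c2)cc1)c1cc2cnccc2[nH]1` gives 14 nM in this assay. Compound 2 `O=C(NCc1ccc(S(=O)(=O)N2CCCCC2)cc1)c1cc2cnccc2s1` gives 1600 nM, the higher of the two numbers shown, with compound 3 far below it, beyond the scatter.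

Compound 4 `O=C(NCc1ccc(S(=O)(=O)N2CCCCC2)cc1)c1cc2ccncc2[nH]1` differs from compound 2 by a group of 9 heavy atoms (7 carbon, 2 nitrogen; one five-membered aromatic ring with 1 hetero atom, one six-membered aromatic ring with 1 hetero atom) in place of a group of 9 heavy atoms (7 carbon, 1 nitrogen, 1 sulfur; one five-membered aromatic ring with 1 hetero atom, one six-membered aromatic ring with 1 hetero atom), on a carbonyl carbon. Among the measured compounds shown here, no measured pair spans this change on its own. Compound 3, whose core likewise carries a hydrogen-bond donor, gives 14 nM, so a drop is expected for compound 4. The expected step of an 11-fold lower number from compound 2 to compound 4 (1.03 log units; beyond the scatter) is a fall beyond the scatter. Compound 4 is estimated at 150 nM, between 30 nM and 1200 nM.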

Compound 4, half-maximal inhibitory concentration: 1700 nM
Estimate against measurement, compound 4: 11-fold (1.05 log units) below, and the stated range ends below it.
By their numbers in this assay, from the lowest: compound 3; then compounds 2 and 4 (each within the scatter of the next). At a limit, above all of these: compound 1.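

In this assay, the exchange on the carbonyl carbon gives a 1.1-fold higher number from compound 2 to compound 4 (0.03 log units; within the scatter). With the piperidine sulfonamide unchanged, replacing the sulfur-containing group, with 0 hydrogen-bond donors, by the group with 1 hydrogen-bond donor therefore brings no change in this read-out. Nothing measured here accounts for this result. The compounds shown leave open whether the same exchange stays just as silent when an aryl group replaces the piperidine on the sulfonyl. They also leave open how another amine there, such as morpholine, would behave with either core.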